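From 2-bromobenzyl to allyl in compound 3

A few compounds are considered here, and "the series" means these few. Any claim that something is new, unique, unknown or untested is made for them only; others in the source may bear on it.

Compound 1 `C[C@@H]1CCN(c2cc(-c3ccccc3)nc3ncnn23)C[C@@H]1N(C)c1ncnc2[nH]ccc12`: > 100000 nM (a limit)
Compound 2 `Cc1cc(N2CC[C@@H](C)[C@@H](N(C)c3ncnc4[nH]ccc34)C2)n2nc(SCc3ccccc3Br)nc2n1`: 21300 nM

Going by the values given here, in a functional assay on HGC-27 cells (Homo sapiens) for inhibition, read by MTT assay, with a stated time of 72 h (a lower number here means a stronger inhibitor, a higher number a weaker inhibitor), compound 2 stands at 21300 nM as the only actual number so far. The entry for compound 1 is a limit of the assay, not a number. Compound 3 (`C=CCSc1nc2nc(C)cc(N3CC[C@@H](C)[C@@H](N(C)c4ncnc5[nH]ccc45)C3)n2n1`) keeps the core of compound 2 and changes in one place (vinyl in place of 2-bromophenyl on a saturated chain carbon bound to a sulfur): vinyl in place of 2-bromophenyl on a saturated chain carbon bound to a sulfur. Among the compounds with values here, no measured step bears on this change. A modest move toward weaker inhibition is expected in this assay as the estimated step (a 1.9-fold higher number from compound 2 to compound 3 (0.27 log units; within the scatter)) somewhat beyond the scatter. The estimate for compound 3 is 40000 nM with 15000 nM to 100000 nM as its expected range.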

Compound 3, half-maximal inhibitory concentration: 35200 nM
The estimate for compound 3 lay 1.1-fold (0.06 log units) above the measured number; the measured number falls inside the stated range.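

In this assay, going by these compounds alone, the one step that can be read gives a 1.7-fold higher number from compound 2 to compound 3 (0.22 log units; within the scatter) for vinyl in place of 2-bromophenyl on a saturated chain carbon bound to a sulfur, and it shows what the earlier compounds alone could not. At this place, the 2-bromobenzyl and allyl groups cannot be told apart, although the aromatic ring and its bromine are gone. Nothing shown accounts for this result.

From the compounds shown here alone, whether an amine or a carboxylic acid at this place would read the same remains open. So does the outcome for a longer chain.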